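Para-substituent change on the benzyl group in a cytotoxicity series

A few compounds are considered here, and "the series" means these few. Any claim that something is new, unique, unknown or untested is made for them only; others in the source may bear on it.

Measured compounds:
compound 1, `O=c1ccoc2cc(OCc3cn(Cc4ccc([N+](=O)[O-])cc4)nn3)ccc12`: > 100000 nM
compound 2, `O=c1ccoc2cc(OCc3cn(Cc4ccccc4Cl)nn3)ccc12`: > 100000 nM
compound 3, `O=c1ccoc2cc(OCc3cn(Cc4ccc(Cl)cc4)nn3)ccc12`: > 100000 nM

In a functional assay on A549 cells (Homo sapiens) for cytotoxicity, read by MTT assay, with a stated time of 48 h (a higher number here means a weaker inhibitor, a lower number a stronger inhibitor), compound 1 gives only a limit, > 100000 nM. In this assay compound 2 likewise gives only a limit, > 100000 nM. Compound 3 also gives only a limit in this assay, > 100000 nM. Because of the limit of > 100000 nM in this assay, at which 3 of the 3 values shown sit, none of the three steps among them can be read: a step that the two limits leave unreadable from compound 1 to compound 2, a step that the two limits leave unreadable from compound 1 to compound 3 and a step that the two limits leave unreadable from compound 2 to compound 3 are all unreadable in size and direction. Compound 3 therefore stands at the limit, together with the two other measured compounds.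

Compound 4, `COc1ccc(Cn2cc(COc3ccc4c(=O)ccoc4c3)nn2)cc1`, differs from compound 3 by methoxy in place of chloro on an aromatic carbon. Within the data shown here, no measured step bears on this change in a readable way, since every step among the measured compounds is capped by the limit. On the numbers shown, compound 4 is expected to sit where compound 3 sits, so the estimated step is a number no higher from compound 3 to compound 4 (the limit leaves the size open), no change beyond the scatter. Compound 4 is estimated at 100000 nM in this assay, within 30000 nM to 300000 nM, with the assay most likely again reporting only a limit.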

Compound 4, half-maximal inhibitory concentration: 16500 nM
For compound 4 the middle estimate is 6.1-fold (0.78 log units) above the measured one; the whole stated range lies above it.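

In this assay, the aromatic carbon para to a large group proves able to move the read-out, with methoxy in place of chloro giving an at least 6.0-fold lower number from compound 3 to compound 4 (0.78 log units; beyond the scatter). Against the other two limit compounds the result is the same: methoxy in place of nitro gives an at least 6.0-fold lower number from compound 1 to compound 4 (0.78 log units; beyond the scatter), and 4-methoxyphenyl in place of 2-chlorophenyl gives an at least 6.0-fold lower number from compound 2 to compound 4 (0.78 log units; beyond the scatter). The steps among compound 1, compound 2 and compound 3 remain unreadable, and the three steps to compound 4 fix only a minimum size because of a limit: the limit of > 100000 nM in this assay, at which 3 of the 4 values shown sit.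

Compound 4 alone carries a readable value, so nothing shown tells whether this shift belongs to methoxy specifically or would also come with a hydroxyl, an ethoxy or a dimethylamino group on the same carbon. Whether methoxy on another carbon of the ring acts alike also stays open, since compound 2 is the only compound shown with its group elsewhere on the ring, and that group is chloro.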